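From Fluoro to Nitro on an Aromatic Carbon

The source may report more compounds than this note shows. Statements on the series, on what has been measured and on what is new or still open speak of the compounds shown alone.

Measured compounds in a functional assay on MDA-MB-231 cells (Homo sapiens) for inhibition, read by sulforhodamine B assay; on this read-out higher numbers stand for weaker inhibition of growth and lower numbers for stronger inhibition of growth:
Compound 1 `COc1ccccc1CN1CCC=C(CCC(=O)NO)C1=O`: > 10000 nM (a limit)
Compound 2 `O=C(CCC1=CCCN(Cc2ccc(F)cc2)C1=O)NO`: "not determined" (no result reported)
Compound 3 `O=C(CCC1=CCCN(Cc2ccc3ccccc3c2)C1=O)NO`: "not determined" (no result reported)

Compound 2 has no single number in this assay and so has no measured standing of its own. Compound 3 is in the same position, with no result to set beside it. Within the data shown here, the one reading available comes from compound 1 (the limit of > 10000 nM in this assay, at which 1 of the 3 values shown sits), and it is a limit rather than a number.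

The next compound, compound 4 (`O=C(CCC1=CCCN(Cc2ccc([N+](=O)[O-])cc2)C1=O)NO`), has yet to be measured. It carries one structural change (nitro in place of fluoro on an aromatic carbon): nitro in place of fluoro on an aromatic carbon, para to a large group.

No measured step exists among these compounds, so the size of this change in this assay cannot be read from the data. The expectation is for no step beyond the usual scatter, with neither direction favoured. Any estimate must lean on compound 1 alone (> 10000 nM), and that value is a limit. A result reported only as a limit is therefore a real possibility for the new compound.

For compound 4 the expected value is 9000 nM with an estimated range from 2500 nM to 30000 nM on this read-out.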

Compound 4, concentration for 50% growth inhibition: 470 nM
The estimate for compound 4 lay 19-fold (1.28 log units) above the measured number; measured number below the stated range.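

No new step can be read from this result, since compound 2 carries no number to set against compound 4, and compound 3 has none either. Compound 1 offers only a limit: the limit of > 10000 nM in this assay, at which 1 of the 4 values shown sits. The compounds shown leave open how much of the growth inhibition by compound 4 goes with nitro in place of fluoro.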